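Changing the Arm on the Sulfur-Bound Carbon

This account rests on a few compounds, and the source may have more. Where it says the series, first, only, none or still open, it means among the compounds named here.

Compound 1: `Cc1cc(-c2ccccc2)n(/C(N)=N/S(=O)(=O)c2cc(C)c(Cl)cc2SCc2cccc3ccccc23)n1` gives 0.256 h
Compound 2: `Cc1cc(-c2ccccc2)n(/C(N)=N/S(=O)(=O)c2cc(C)c(Cl)cc2SCc2ccccc2C)n1` gives 0.154 h
Compound 3: `Cc1cc(S(=O)(=O)/N=C(\N)n2nccc2-c2ccccc2)c(SCc2cccc3ccccc23)cc1Cl` gives 0.268 h

All three values come from an ADME assay on microsomes from liver (Homo sapiens) for metabolic stability, read by LC-MS, using NADPH, tested at 5 uM; a higher number here means that the compound lasts longer, a lower number that the compound disappears faster. Compound 3 stands close beside the others: the step of a 1.0-fold higher number from compound 1 to compound 3 (0.02 log units; within the scatter) is within the scatter, and the gap between compound 3 and compound 2 is also of a size that repeated runs of this assay would not resolve. On these numbers the three compounds cannot be told apart.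

Compound 4, `Cc1cc(S(=O)(=O)/N=C(\N)n2nccc2-c2ccccc2)c(SCc2ccccc2C(F)(F)F)cc1Cl`, is the next compound and has not yet been measured. It differs from compound 3 in one place: 2-(trifluoromethyl)phenyl in place of naphthalen-1-yl on a saturated chain carbon bound to a sulfur. Within the data shown here, one measured step bears on this kind of change, the swap of the same naphthalen-1-yl group for a 2-methylphenyl group in the step of a 1.7-fold lower number from compound 1 to compound 2 (0.22 log units; within the scatter), which stayed within the scatter. Among the measured compounds shown here, with only that step as a guide, the expectation is that the change from compound 3 to compound 4 gives a small drift, a 1.2-fold lower number from compound 3 to compound 4 (0.09 log units; within the scatter), and no clear movement beyond the scatter in this assay. Compound 4 is therefore estimated at 0.22 h, with a range from 0.1 h to 0.45 h.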

Compound 4, half-life: 0.15 h
Estimate against measurement, compound 4: 1.5-fold (0.17 log units) above, and the stated range covers the measured number.
By their numbers in this assay, from the lowest: compounds 4, 2, 1 and 3 (each within the scatter of the next).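

In this assay, the step of a 1.8-fold lower number from compound 3 to compound 4 (0.25 log units; within the scatter) gives a second reading of what happens when naphthalen-1-yl is replaced on the saturated chain carbon bound to a sulfur. Here the two six-membered aromatic rings of naphthalen-1-yl give way to the single ring of 2-(trifluoromethyl)phenyl, and this swap, like the earlier one to 2-methylphenyl, does not move the half-life beyond the usual scatter, so within the four compounds shown, this position tolerates a change from naphthalen-1-yl to either of two substituted phenyl groups, on two slightly different cores, without a resolved change in stability. Nothing measured here explains why the half-life responds so little to these swaps.

Every arm shown on this carbon is aromatic and carbon-ringed, so it remains open whether an amine, a carboxylic acid or a longer alkyl chain in that place would shift the half-life clearly. From the compounds shown here alone, it is equally open whether the pattern would hold for a plain phenyl group, which would show what the 2-methyl and 2-trifluoromethyl groups contribute on their own.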